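A few compounds are considered here, and "the series" means these few. Any claim that something is new, unique, unknown or untested is made for them only; others in the source may bear on it.

Measured so far:

Compound 2, `CC(C)CC(=O)Nc1ncc(-c2cccc(Cl)c2)c(-c2ccccc2)n1`, gives 56% in an assay on CHO cells for displacement of a labelled ligand from adenosine receptor A1 (Homo sapiens), read by scintillation counting, with a stated time of 1 h, tested at 1 uM; a higher number here means more inhibition at the concentration tested (going by the name of the read-out), a lower number less inhibition.
Compound 1, `Nc1ncc(-c2ccc(OCc3ccccc3)c(Cl)c2)c(-c2ccccc2)n1`, gives 38% in this assay.

Of the two numbers, compound 2 stands highest; its nearest neighbour, compound 1, lies lower by an amount beyond the usual scatter of this kind of measurement. The next compound, compound 3, `CC(C)Nc1ncc(-c2cccc(Cl)c2)c(-c2ccccc2)n1`, has not yet been measured. It differs from compound 2 in a single place: isopropyl in place of isobutylcarbonyl on a nitrogen on an aromatic ring. Among the measured compounds no pair isolates this particular change, so there is no measured step to lean on, and the expectation rests on the structural change alone. Compound 3 is estimated to give about 40%, with a plausible range from 15% to 65%. The step expected from compound 2 to compound 3 is therefore a number 16 percentage points lower from compound 2 to compound 3 (beyond the scatter), a moderate fall, though one that could still turn out to lie within the scatter.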

Compound 3, a percentage reported as inhibition, at one concentration (the size of the read-out at that concentration, not a potency): 71%
Compound 3: the middle estimate sits 31 percentage points below what was measured; measured number above the stated range.
By their numbers in this assay, from the lowest: compound 1; then compound 2; then compound 3.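

At this position, on a nitrogen on an aromatic ring, the isobutylcarbonyl group is not required for activity in this assay: replacing it with isopropyl gives a number 15 percentage points higher from compound 2 to compound 3 (beyond the scatter). The entering group has fewer heavy atoms and no hydrogen-bond acceptor, so the amide carbonyl can be lost here without any drop in the read-out. However, the carbonyl and the chain change together in this single step, and nothing measured here explains the rise.

These compounds cannot show whether removing the carbonyl or shortening the chain matters more. An acetyl group or a longer chain such as n-butyl on the same nitrogen would help separate the two, and a cyclopropyl group would test whether a ring is accepted there.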